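Five-membered ring in place of phenyl on the core

The source may hold more compounds than are shown below. What is called first, only, known or untested is meant among the compounds shown, and "the series" means these compounds.

Compound 1 `Cc1nc(N)c2c(-c3cc4ccccc4o3)cn([C@@H]3O[C@H](CO)[C@@H](O)[C@H]3O)c2n1` gives 13100 nM in a functional assay on HCT-116 cells (Homo sapiens), read by MTT assay, with a stated time of 72 h; on this read-out higher numbers stand for weaker inhibition and lower numbers for stronger inhibition. Compound 2 `Cc1nc(N)c2c(-c3cccs3)cn([C@@H]3O[C@H](CO)[C@@H](O)[C@H]3O)c2n1` reaches only the assay limit in this assay, > 20000 nM. Compound 3 `Cc1nc(N)c2c(-c3ccccc3)cn([C@@H]3O[C@H](CO)[C@@H](O)[C@H]3O)c2n1` likewise stops at the limit, > 20000 nM. Compound 3 therefore stands at the limit, as does compound 2 (the limit of > 20000 nM in this assay, at which 2 of the 3 values shown sit). Compound 4 `Cc1nc(N)c2c(-c3ccoc3)cn([C@@H]3O[C@H](CO)[C@@H](O)[C@H]3O)c2n1` carries a change of furan-3-yl in place of phenyl on an aromatic carbon. Among the compounds with values here, the steps that bear on it are an at least 1.5-fold higher number from compound 1 to compound 2 (0.18 log units; that floor lies within the scatter) and an at least 1.5-fold higher number from compound 1 to compound 3 (0.18 log units; that floor lies within the scatter), both floors within the scatter, while a step that the two limits leave unreadable from compound 2 to compound 3. Exchange of one aryl group on this carbon for another has not yet moved any value beyond the scatter, so for compound 4 no step beyond the scatter is expected, a step that the limit leaves unreadable from compound 3 to compound 4, most likely another limit. Compound 4 is expected at 30000 nM, with a range of 10000 nM to 90000 nM.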

Compound 4, half-maximal inhibitory concentration: > 20000 nM
Compound 4 gave a limit, no number (the forecaster's own chance of this, stated with the estimate: 70%); the middle value does not contradict the limit.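

Furan-3-yl, with its ring oxygen, leaves this aromatic carbon as uninformative as thiophen-2-yl and phenyl did in this assay, so three single-ring groups now end alike: the limit of > 20000 nM in this assay, at which 3 of the 4 values shown sit. Against the 1-benzofuran-2-yl group, the reading is an at least 1.5-fold higher number from compound 1 to compound 4 (0.18 log units; that floor lies within the scatter). The steps among compound 2, compound 3 and compound 4 cannot be read.

Still open, on these data alone, is whether the 1-benzofuran-2-yl group truly differs from any single-ring group, since every floor lies within the scatter. Also open, as far as these compounds go, is whether an amine or a carboxylic acid on the aryl ring would give a readable number.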